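Swapping a Hydroxy for an Acetamido on a Shared Core

The compounds below may be only part of what the source reports. "The series", "measured", "known", "first", "only" and "open" are said of these compounds alone.

Of the compounds shown here, three share a related scaffold and have been tested in a functional assay for inhibition, with Homo sapiens as the target; a higher number here means a weaker inhibitor, a lower number a stronger inhibitor. Compound 2 `CC1CCN(c2ccc(Nc3nccc(-c4ccncc4)n3)cc2)CC1` gives 600 nM, compound 3 `Oc1ccc(Nc2nccc(-c3ccncc3)n2)cc1` gives 3300 nM, and compound 1 `CC(=O)Nc1ccc(Nc2nccc(-c3cccnc3)n2)cc1` gives 3600 nM. Compound 3 therefore stands second highest of the three numbers: its value and that of compound 1 lie within the scatter of each other, while a 5.5-fold higher number from compound 2 to compound 3 (0.74 log units; beyond the scatter) is a modest step beyond it.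

Compound 4 `CC(=O)Nc1ccc(Nc2nccc(-c3ccncc3)n2)cc1` has not yet been measured in this assay. The change from compound 3 is acetamido in place of hydroxy on an aromatic carbon. For the measured compounds named here, no measured step covers this exact swap; the one measured step, from compound 2 to compound 3, concerns a different group. Compound 1, however, already carries the acetamido group on a core that differs only slightly, and its value sits within the scatter of compound 3. The expected step of a 1.1-fold higher number from compound 3 to compound 4 (0.03 log units; within the scatter) is therefore none beyond the scatter. Compound 4 is estimated at 3500 nM, within a range from 1500 nM to 8000 nM.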

Compound 4, half-maximal inhibitory concentration: 5300 nM
Beside the measured number, compound 4's estimate is 1.5-fold (0.18 log units) below it; the range from low to high includes it.
By their numbers in this assay, from the lowest: compound 2; then compounds 3, 1 and 4 (each within the scatter of the next).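

In this assay, acetamido in place of hydroxy on the shared core (a 1.6-fold higher number from compound 3 to compound 4 (0.21 log units; within the scatter)) leaves the two compounds within the usual scatter, although acetamido is the larger group by heavy atoms. The other one-place change to compound 4, pyridin-4-yl in place of pyridin-3-yl (a 1.5-fold higher number from compound 1 to compound 4 (0.17 log units; within the scatter)), also stays within the scatter, so neither change can be read as shifting the number. Only 4-methylpiperidin-1-yl stands apart at the position para to a large group: acetamido in its place (an 8.8-fold higher number from compound 2 to compound 4 (0.95 log units; beyond the scatter)) goes beyond the scatter, as hydroxy did.

Going by these compounds, whether the gain belongs to the ring, to its methyl or to its nitrogen stays open, and an unsubstituted piperidine, a morpholine or a simple amine at this position would help separate these. Nothing here explains the difference.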